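From Methoxy to Hydroxymethyl on a Shared Core

The source may report more compounds than this note shows. Statements on the series, on what has been measured and on what is new or still open speak of the compounds shown alone.

Compound 1 `CCOC(=O)c1c(-c2cccc(OC)c2)[nH]c2cc(OC)ccc2c1=O` was tested in an ADME assay on Raji cells (Homo sapiens) for cytotoxicity, read by luminescence, with a stated time of 72 h; a higher number here means that more compound is needed for the effect, a lower number that less compound is needed. In this assay compound 1 reaches only a limit of the assay, namely > 21500 nM. Compound 2 `CCOC(=O)c1c(-c2cccc(C(F)(F)F)c2)[nH]c2cc(OC)ccc2c1=O` likewise gives only a limit in this assay, > 21500 nM. The step that the two limits leave unreadable from compound 1 to compound 2 cannot be read in size, and the limit of > 21500 nM in this assay, at which 2 of the 2 values shown sit, shows where both values sit. Compound 3 `CCOC(=O)c1c(-c2cccc(CO)c2)[nH]c2cc(OC)ccc2c1=O` differs from compound 1 by hydroxymethyl in place of methoxy on an aromatic carbon. Among the measured compounds shown here, no measured step gives a readable size, so nothing beyond the scatter is expected in this assay. Compound 3 is expected to give about 30000 nM, between 10000 nM and 100000 nM. The step that the limit leaves unreadable from compound 1 to compound 3 is therefore estimated to stay near the limit.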

Compound 3, half-maximal effective concentration: > 21500 nM
Compound 3 was reported as a limit (the forecaster's own chance of this, stated with the estimate: 85%); the middle value does not contradict the limit.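

No new step can be read among compound 1, compound 2 and compound 3, whose values all remain limits: the limit of > 21500 nM in this assay, at which 3 of the 3 values shown sit. The compounds shown leave open whether methoxy, trifluoromethyl and hydroxymethyl differ in this assay at all.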